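One Halogen Swap on the Outer Phenyl Ring

A few compounds are considered here, and "the series" means these few. Any claim that something is new, unique, unknown or untested is made for them only; others in the source may bear on it.

Measured compounds:
Compound 1, `COc1cc(Br)ccc1Nc1cc(NC(=O)Nc2c(Cl)cccc2Cl)ncn1`, gives 47.3%.
Compound 2, `COc1cc(Nc2cc(NC(=O)Nc3c(Cl)cccc3Cl)ncn2)cc(OC)c1`, gives 68%.
Compound 3, `COc1cc(NC(=O)Nc2cc(Nc3ccc(C)c(F)c3)ncn2)cc(OC)c1`, gives 38%.

All three numbers come from a functional assay on NCI-H1581 cells (Homo sapiens) for inhibition, read by MTT assay, with a stated time of 48 h, tested at 10 uM; on this read-out lower numbers stand for less inhibition and higher numbers for more inhibition at the one concentration tested (going by the name of the read-out). Compound 3 has the lowest of the three numbers. Its nearest neighbour is compound 1, whose value lies within the usual scatter of this measurement, so the two cannot be ordered. Compound 2 lies furthest away, with a value beyond the scatter, so compound 2 shows clearly more inhibition than compound 3.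

Compound 4, `COc1cc(NC(=O)Nc2cc(Nc3ccc(F)c(Cl)c3)ncn2)cc(OC)c1`, has not been measured. It differs from compound 3 in one place: 3-chloro-4-fluorophenyl in place of 3-fluoro-4-methylphenyl on a nitrogen on an aromatic ring. Both groups that leave and enter are a single six-membered aromatic ring of carbon only, with no hydrogen-bond donors or acceptors and no net charge; only the pattern of halogen and methyl on that ring changes.

Going by the values given here, no measured pair shows what such a swap does in this assay. Without such a comparison, the expected step from compound 3 to compound 4 is small, as a number 4 percentage points higher from compound 3 to compound 4 (within the scatter), and not beyond the scatter in either direction. Compound 4 is therefore expected to give about 42% in this assay, with a likely range from 25% to 60%.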

Compound 4, a percentage reported as inhibition, at one concentration (the size of the read-out at that concentration, not a potency): 53%
Compound 4: middle estimate off by 11 percentage points, on the low side; measured number inside the range.
By their numbers in this assay, from the lowest: compounds 3, 1 and 4 (each within the scatter of the next, the first and the last beyond it); then compound 2.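

In this assay, the group on the nitrogen on an aromatic ring turns out to matter: 3-chloro-4-fluorophenyl in place of 3-fluoro-4-methylphenyl gives a number 15 percentage points higher from compound 3 to compound 4 (beyond the scatter). Going by these compounds alone, this is the first comparison here between two compounds that differ in one place, and it shows that the read-out can move even when the aromatic ring of carbon only, the count of heavy atoms, the lack of hydrogen-bond donors and acceptors, and the lack of net charge all stay the same. No supporting measurement is available to explain this step, so it stands as an observation only.

A single pair cannot separate the chlorine that enters, the methyl that leaves and the altered placing of the fluorine, so it remains open which of these changes accounts for the step. Also open, from the compounds shown here alone, is whether the number in this assay would be higher, lower or level with a plain phenyl ring or a ring carrying a nitrile or a dimethylamino group on this nitrogen, and whether the same swap would produce a similar step on the core of compound 2.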